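Thiourea in place of cyanoguanidine on the chain nitrogen

This account rests on a few compounds, and the source may have more. Where it says the series, first, only, none or still open, it means among the compounds named here.

The set shares the core of compound 1 `C/N=C(/NC#N)NCCCCCCn1nc(-c2ccccc2)ccc1=O`, a chain carrying a cyanoguanidine-type group, and is read in a functional assay on the whole organism (stomach) with Rattus norvegicus as the target; a lower number here means that less compound is needed, a higher number that more compound is needed for the effect. In this assay compound 1 reaches only a limit, > 100 mg/kg. Compound 3 `CC/N=C(/NC#N)NCCCCCCn1nc(-c2ccccc2)ccc1=O` likewise reaches only a limit, > 100 mg/kg. The step that the two limits leave unreadable from compound 1 to compound 3 is thus not readable, both values sitting at the limit of > 100 mg/kg in this assay, at which 2 of the 3 values shown sit. For the measured compounds named here, compound 2 `N#CNC(=N)NCCCCn1nc(-c2ccccc2)ccc1=O` gives 77.2 mg/kg in this assay, the only number in the set. The other two values of the set are limits.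

Compound 4 `CC/N=C(\S)NCCCCn1nc(-c2ccccc2)ccc1=O` differs from compound 2 by a group of 5 heavy atoms (3 carbon, 1 nitrogen, 1 sulfur; no ring) in place of a group of 5 heavy atoms (2 carbon, 3 nitrogen; no ring), on an amine nitrogen. Going by the values given here, no measured step bears on this change: the single recorded step lies between two limits and concerns methyl in place of hydrogen on a saturated chain carbon bound to a double-bonded nitrogen, a change of another kind. The step from compound 2 to compound 4 is therefore expected to be a 1.0-fold higher number from compound 2 to compound 4 (0.02 log units; within the scatter), within the usual scatter and with no direction favoured. Compound 4 is estimated at 80 mg/kg, between 30 mg/kg and 200 mg/kg, with a fair chance that only a limit is reported.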

Compound 4, dose for half-maximal effect: 37.2 mg/kg
Beside the measured number, compound 4's estimate is 2.2-fold (0.33 log units) above it; the measured number falls inside the stated range.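

For the compounds shown here, the first readable step comes from this change on the amine nitrogen: in this assay, the thiourea-type group gives a 2.1-fold lower number from compound 2 to compound 4 (0.32 log units; beyond the scatter). The effect in this assay therefore does not depend on the cyanoguanidine, and the amine nitrogen of this chain tolerates a group with sulfur in place of the nitrile-bearing nitrogen, with fewer hydrogen-bond donors and acceptors counted on the entering group. Nothing shown here accounts for the size or direction of this modest step.

From the compounds shown here alone, compound 1 and compound 3 are both limits, the step between them cannot be read, and whether the thiourea-type group gives the same change on their chain stays open. Also open, going by these compounds, is what a urea or a plain amine would give in this place on the chain of compound 2.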